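The source may report more compounds than this note shows. Statements on the series, on what has been measured and on what is new or still open speak of the compounds shown alone.

Among the measured compounds shown here, compound 1 `COc1cc(-c2cc(/C=C/C(=O)c3ccc(N)cc3)[nH]n2)cc(OC)c1OC` stands as the highest of the two numbers measured so far: in a functional assay on PC-3 cells (Homo sapiens) for cytotoxicity, read by sulforhodamine B assay, with a stated time of 48 h, tested at 100 uM (on this read-out higher numbers stand for a weaker effect at the one concentration tested and lower numbers for a stronger effect), compound 1 gives -39%, while compound 2 `COc1ccc(-c2cc(/C=C/C(=O)c3ccc(OC)c(OC)c3)[nH]n2)cc1` in this assay gives -90%, a gap beyond the scatter. Compound 3 `COc1cc(-c2cc(/C=C/C(=O)c3ccc(Cl)c(Cl)c3)[nH]n2)cc(OC)c1OC` has not yet been measured. It differs from compound 1 in one place: 3,4-dichlorophenyl in place of 4-aminophenyl on a carbonyl carbon. For the measured compounds named here, no step between measured compounds isolates this change, so the expected step of a number 21 percentage points lower from compound 1 to compound 3 (beyond the scatter) is a guess, leaning toward lower numbers. Compound 3 is estimated to give -60% in this assay, within a range from -95% to -20%.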

Compound 3, a percentage reported as activity, at one concentration (the size of the read-out at that concentration, not a potency): 10%
Compound 3: middle estimate off by 70 percentage points, on the low side; measured number outside the range, above it.
By their numbers in this assay, from the lowest: compound 2; then compound 1; then compound 3.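

In this assay, placing 3,4-dichlorophenyl in place of 4-aminophenyl on the carbonyl carbon gives a number 49 percentage points higher from compound 1 to compound 3 (beyond the scatter). The group on this carbonyl carbon therefore matters to the read-out, and of these two groups, 4-aminophenyl goes with the stronger effect. Nothing available explains the size of this step.

The change removes the amine and adds both chlorines in a single step, so the compounds shown cannot tell which part of the swap carries the loss. Going by these compounds, how an unsubstituted phenyl or a 4-hydroxyphenyl at this place would read remains open.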